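Swapping a Nitro Group for Benzylamino on a Shared Core

The compounds below may be only part of what the source reports. "The series", "measured", "known", "first", "only" and "open" are said of these compounds alone.

Measured so far in a functional assay on A549 cells (Homo sapiens) for antiproliferative activity, read by MTT assay, with a stated time of 72 h; a lower number here means a stronger inhibitor of growth, a higher number a weaker inhibitor of growth:
compound 1 `CC(C)Cn1c(SCc2ccccc2)nc(N)cc1=O`: 83300 nM
compound 2 `CC(=O)Nc1cc(=O)n(Cc2ccccc2)c(SCc2ccccc2)n1`: 50400 nM
compound 3 `COc1cc(OC)n2cc(-c3ccc([N+](=O)[O-])cc3)nc2n1`: 36600 nM

Compound 3 has the lowest number of the three, but compound 2 sits within the usual scatter of it, so no order between those two can be claimed; only compound 1 lies beyond the scatter, with the higher number. The next compound, compound 4 `COc1cc(OC)n2cc(-c3ccc(NCc4ccccc4)cc3)nc2n1`, keeps the core of compound 3 and differs in one place: benzylamino in place of nitro on an aromatic carbon. Within the data shown here, no measured pair shows this change, so its size is unknown. The expected step is a 1.8-fold lower number from compound 3 to compound 4 (0.26 log units; within the scatter), a modest move toward a lower number, not far beyond the scatter. Compound 4 is estimated at 20000 nM, within a range from 5000 nM to 80000 nM.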

Compound 4, concentration for 50% growth inhibition: > 100000 nM
Compound 4: no number, only a limit; the forecaster's own chance of this, stated with the estimate: 10%; middle value at least 5.0-fold (0.69 log units) away from the limit.
By their numbers in this assay, from the lowest: compounds 3, 2 and 1 (each within the scatter of the next, the first and the last beyond it). At a limit, above all of these: compound 4.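

In this assay compound 4 gives > 100000 nM, a limit of the assay and not a number. Benzylamino in place of nitro on this aromatic carbon therefore gives an at least 2.7-fold higher number from compound 3 to compound 4 (0.43 log units; beyond the scatter), so the change moves growth inhibition in the weakening direction on the shared core. The full size of the step cannot be read, because only a limit is available: the limit of > 100000 nM in this assay, at which 1 of the 4 values shown sits.

The compounds shown leave open whether this shift goes with the removal of nitro or with the arrival of the benzyl ring. A plain amine on the same carbon would help separate the two.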